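This account rests on a few compounds, and the source may have more. Where it says the series, first, only, none or still open, it means among the compounds named here.

Measured compounds:
- compound 1 `N#Cc1ccc(Nc2nc(Oc3ccc(Cl)cc3)c3ccccc3n2)cc1`: 198000 nM
- compound 2 `COc1cc(C#N)cc(Cl)c1Oc1nc(Nc2ccc(C#N)cc2)nc2ccccc12`: 220000 nM
- compound 3 `Cc1cc(C#N)cc(C)c1Oc1nc(Nc2ccc(C#N)cc2)nc2ccc(Cl)cc12`: 117000 nM

In an ADME assay on MT4 cells (Homo sapiens) for cytotoxicity, read by MTT assay, with a stated time of 4 days (on this read-out higher numbers stand for lower toxicity in this test and lower numbers for higher toxicity in this test), compound 1 gives 198000 nM and stands second highest of the three numbers. Its nearest neighbour is compound 2, whose value lies within the scatter of it; the furthest is compound 3, and that gap too stays within the scatter. Among the measured compounds shown here, no step between measured compounds differing in one place is available, so nothing in the measured set shows what a single change does here.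

Compound 4 `N#Cc1ccc(Nc2nc(Oc3ccccc3)c3ccccc3n2)cc1` is the unmeasured analogue. Its difference from compound 1 is hydrogen in place of chloro on an aromatic carbon. The loss of the chloro is a small change on the outer ring of the shared core. The step of a 1.0-fold higher number from compound 1 to compound 4 (0.00 log units; within the scatter) is expected to be no larger than the scatter, in no firm direction. Compound 4 is therefore estimated at 200000 nM, within 100000 nM to 400000 nM.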

Compound 4, half-maximal cytotoxic concentration: 370000 nM
Beside the measured number, compound 4's estimate is 1.9-fold (0.27 log units) below it, within the range that was stated.
By their numbers in this assay, from the lowest: compounds 3, 1, 2 and 4 (each within the scatter of the next, the first and the last beyond it).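

The change from 4-chlorophenyl to phenyl gives the series its first single-place step in this assay (a 1.9-fold higher number from compound 1 to compound 4 (0.27 log units; within the scatter)). At this position, para to a large group, hydrogen can thus replace chloro without a step beyond the scatter. No evidence on the cause of this step is available.

An amine or a carboxylic acid at this position remains untested in the compounds shown. This single pair also leaves open whether the same exchange would stay within the scatter on the more substituted outer rings of compound 2 and compound 3.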